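A few compounds are considered here, and "the series" means these few. Any claim that something is new, unique, unknown or untested is made for them only; others in the source may bear on it.

Of the compounds shown here, two sharing one core have been tested so far in a functional assay on T47D cells (Homo sapiens) for cytotoxicity, read by sulforhodamine B assay, with a stated time of 48 h, tested at 100 nM; a higher number here means a weaker effect of the compound at the concentration tested, a lower number a stronger effect. Compound 1, `COc1cc(C)cc(-c2c(-c3ccnc(-c4ccc(C(C)=O)cc4)c3)cnn2CC#N)c1`, gives 87% in this assay, the highest of the two numbers seen. Compound 2, `COc1cc(C)cc(-c2nn(CC#N)cc2-c2ccnc(-c3ccc(N(C)C)cc3)c2)c1`, gives 24%, a far lower number, well beyond the usual scatter of such measurements; the two structures differ in more than one place, so this gap cannot be tied to a single change. Compound 3, `COc1cc(C)cc(-c2c(-c3ccnc(-c4ccc(N(C)C)cc4)c3)cnn2CC#N)c1`, has not yet been measured. It differs from compound 1 in one place only: dimethylamino in place of acetyl on an aromatic carbon. Compound 2 also carries a dimethylamino group on its outer ring and shows 24% in this assay. A clear step downward, towards a stronger effect, is therefore expected for compound 3, of the size a number 47 percentage points lower from compound 1 to compound 3 (beyond the scatter). Compound 3 is estimated to give 40%, within a range of 20% to 75%.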

Compound 3, a percentage reported as activity, at one concentration (the size of the read-out at that concentration, not a potency): 44%
Compound 3: the middle estimate sits 4 percentage points below what was measured, within the range that was stated.
By their numbers in this assay, from the lowest: compound 2; then compound 3; then compound 1.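

On a six-membered aromatic ring of carbon only, para to a large group, placing dimethylamino in place of acetyl gives a large change in this assay, a number 43 percentage points lower from compound 1 to compound 3 (beyond the scatter). For the compounds shown here, this is the first change here that can be read in one place, and it shows that this position responds to the group it carries, even though both groups have the same count of heavy atoms and hydrogen-bond acceptors, no ring and no net charge. Nothing measured here explains the step.

The compounds shown leave open whether the stronger effect is specific to dimethylamino or would also appear with a plain amino group or a morpholine. They also leave open how a carboxylic acid at this position would compare with acetyl.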